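This account rests on a few compounds, and the source may have more. Where it says the series, first, only, none or still open, it means among the compounds named here.

Compound 1 `O=C(O)CNC(=O)COc1ccc([C@H]2CC[C@]3(CC2)OOC2(O3)C3CC4CC(C3)CC2C4)cc1`: < 3.1 ug/mL
Compound 2 `O=C(O)c1cccc([C@H]2CC[C@]3(CC2)OOC2(O3)C3CC4CC(C3)CC2C4)c1`: < 1.6 ug/mL

Both compounds were tested in a physicochemical assay for solubility, read by nephelometry, measured as kinetic solubility, with a stated time of 30 min, at pH 2.0; on this read-out lower numbers stand for lower solubility and higher numbers for higher solubility. Compound 2 gives < 1.6 ug/mL, which is a limit of the assay and not a number. Compound 1 also gives a limit, < 3.1 ug/mL. Compound 3 `O=C(O)COc1ccc([C@H]2CC[C@]3(CC2)OOC2(O3)C3CC4CC(C3)CC2C4)cc1C(=O)O` differs from compound 2 by one change: carboxymethoxy in place of hydrogen on an aromatic carbon, ortho to a carboxy group. Within the data shown here, with no measured step to go on, only a modest rise in this assay is expected, hardly beyond the usual scatter. The estimated move is an at least 1.5-fold higher number from compound 2 to compound 3 (0.19 log units; that floor lies within the scatter). For compound 3 the expected value is 2.5 ug/mL, with an estimated range of 1 ug/mL to 7 ug/mL.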

Compound 3, solubility: > 100 ug/mL
Compound 3: only a limit was reported; the forecaster's own chance of this, stated with the estimate: 70%; at least 40-fold (1.60 log units) between middle value and limit.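

In this assay, carboxymethoxy in place of hydrogen on an aromatic carbon, ortho to a carboxy group, gives an at least 62-fold higher number from compound 2 to compound 3 (1.79 log units; beyond the scatter). Among these compounds, this is the first measured step here, and it shows that one added group at this position is enough to move the read-out from the low end to the high end. Compound 3 gives > 100 ug/mL, which is a limit and not a number.

From the compounds shown here alone, the true size of the step stays open, since it rests on limits at both ends. Also open, going by these compounds, is whether a plain methoxy group or an aminoethoxy chain at this position would do the same.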